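A few compounds are considered here, and "the series" means these few. Any claim that something is new, unique, unknown or untested is made for them only; others in the source may bear on it.

Compound 3, `COc1ccc(C(=O)/C=C/c2ccc(OCc3cn(Cc4ccc(Br)cc4)nn3)cc2)cc1`, is one of three compounds tested in a functional assay on MIA PaCa-2 cells (Homo sapiens) for inhibition, read by MTT assay, with a stated time of 48 h, tested at 10 uM; a higher number here means more inhibition of growth at the concentration tested, a lower number less inhibition of growth. In this assay compound 3 gives 56%, the second highest of the three numbers. Compound 1, `O=C(/C=C/c1ccc(OCc2cn(Cc3ccc(Br)cc3)nn2)cc1)c1ccc(Br)cc1`, gives 29%, and compound 2, `COc1ccc(C(=O)/C=C/c2ccc(OCc3cn(Cc4ccccc4)nn3)cc2)cc1`, gives 68%. The step of a number 27 percentage points higher from compound 1 to compound 3 (beyond the scatter) is the larger of the two measured steps that lead to compound 3; the step of a number 12 percentage points lower from compound 2 to compound 3 (beyond the scatter) is smaller and points the other way.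

Compound 4, `COc1ccc(C(=O)/C=C/c2ccc(OCc3cn(Cc4ccc(F)cc4)nn3)cc2)cc1`, has not yet been measured. It differs from compound 3 in one place: fluoro in place of bromo on an aromatic carbon. The change sits on the same benzyl ring that was altered in the step from compound 2 to compound 3, where a bromo entering in place of hydrogen lowered the number beyond the scatter. Fluoro, like the hydrogen of compound 2 and the bromo of compound 3, is a single heavy atom on that aromatic carbon, so compound 4 is expected to sit between compound 2 and compound 3 or close to compound 3. Compound 4 is therefore estimated at 60%, with a range of 45% to 75%. The expected step is a number 4 percentage points higher from compound 3 to compound 4 (within the scatter), which would lie within the usual scatter.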

Compound 4, percent growth inhibition at one concentration: 6%
For compound 4 the middle estimate is 54 percentage points above the measured one, outside the stated range (below it).
By their numbers in this assay, from the lowest: compound 4; then compound 1; then compound 3; then compound 2.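

In this assay, exchanging one halogen for another on this aromatic carbon, para to a large group, is far from neutral: the result is a number 50 percentage points lower from compound 3 to compound 4 (beyond the scatter) in a single change, even though bromo and fluoro each count one heavy atom and neither brings a hydrogen-bond donor or acceptor. Against the unsubstituted benzyl of compound 2, fluoro gives a number 62 percentage points lower from compound 2 to compound 4 (beyond the scatter) and so goes much further than the modest a number 12 percentage points lower from compound 2 to compound 3 (beyond the scatter) seen earlier, which shows that the outcome at this place depends strongly on which halogen stands there, not merely on whether a halogen is present. Nothing measured here accounts for this difference between bromo and fluoro.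

The compounds shown leave open how chloro, or a larger change such as an amine or a carboxylic acid, would behave on this same aromatic carbon. They also leave open whether fluoro would have a comparable effect on the other aromatic ring, where compound 1 and compound 3 differ, and how these compounds would compare across a range of concentrations.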